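This account rests on a few compounds, and the source may have more. Where it says the series, first, only, none or still open, it means among the compounds named here.

Measured so far in an ADME assay on HCT-116 cells (Homo sapiens) for cytotoxicity, read by CellTiter-Glo, with a stated time of 72 h; a higher number here means a weaker inhibitor, a lower number a stronger inhibitor:
- compound 1 `Cc1cc(C)c(S(=O)(=O)N2CCN(C3CN4CCC3CC4)CC2)c(C)c1` gives > 5000 nM as a limit
- compound 2 `Cc1ccc(C2CCN(S(=O)(=O)c3c(C)cc(C)cc3C)CC2)cc1` gives > 5000 nM as a limit

Within the data shown here, the series shows the limit of > 5000 nM in this assay, at which 2 of the 2 values shown sit, and so offers no measured step. Compound 2 stands at a limit and not at a number. Compound 3 `Cc1cc(C)c(S(=O)(=O)N2CCC(N3CC(C)CC(C)C3)CC2)c(C)c1` differs from compound 2 by 3,5-dimethylpiperidin-1-yl in place of 4-methylphenyl on a saturated ring carbon with 3,5-dimethylpiperidin-1-yl in place of 4-methylphenyl on a saturated ring carbon. The limit > 5000 nM of compound 2 is the only anchor for an expectation. No shift beyond the scatter is expected in either direction, and the estimated change is a step that the limit leaves unreadable from compound 2 to compound 3 in this assay here. Compound 3 is estimated at 6000 nM with an expected range from 2500 nM to 15000 nM in this estimate.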

Compound 3, half-maximal inhibitory concentration: > 5000 nM
Compound 3: a limit, no number; the forecaster's own chance of this, stated with the estimate: 75%; the middle value does not contradict the limit.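

In this assay, among these compounds, compound 3 gives > 5000 nM, a limit and not a number, so no step from compound 2 to compound 3 can be read: the limit of > 5000 nM in this assay, at which 3 of the 3 values shown sit. The compounds shown leave open how far any of them lies past that limit.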